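Chloro to dimethylamino on a nitro-bearing compound

The source may hold more compounds than are shown below. What is called first, only, known or untested is meant among the compounds shown, and "the series" means these compounds.

Compound 1 `CN(C)c1ccc(/C=C2\CCC/C(=C\c3ccccc3[N+](=O)[O-])C2=O)cc1`: > 400000 nM, a limit
Compound 2 `O=C1/C(=C/c2ccccc2)CCC/C1=C\c1cccc([N+](=O)[O-])c1`: 14000 nM
Compound 3 `O=C1/C(=C/c2ccc(Cl)cc2)CCC/C1=C\c1cccc([N+](=O)[O-])c1`: 18000 nM

All three compounds were tested in an ADME assay on HPC cells (Homo sapiens) for cytotoxicity, with a stated time of 24 h; on this read-out higher numbers stand for lower toxicity in this test and lower numbers for higher toxicity in this test. Compound 3, at 18000 nM, lies within the scatter of compound 2, at 14000 nM.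

The next compound to be measured is compound 4 `CN(C)c1ccc(/C=C2\CCC/C(=C\c3cccc([N+](=O)[O-])c3)C2=O)cc1`. It differs from compound 3 in one place: dimethylamino in place of chloro on an aromatic carbon. This puts dimethylamino in place of chloro on an aromatic carbon, para to a large group, so 4-chlorophenyl becomes 4-(dimethylamino)phenyl.

Two measurements bear on this change. Within the data shown here, the only measured step at this kind of position is a swap of hydrogen for chloro, a 1.3-fold higher number from compound 2 to compound 3 (0.11 log units; within the scatter). It involves a different pair of groups, so it is a weak guide. Compound 1 also carries the 4-(dimethylamino)phenyl group, and its reading is only a limit, (the limit of > 400000 nM in this assay, at which 1 of the 3 values shown sits). However, its nitro group stands elsewhere than in compound 4, so it offers a hint and no more.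

A moderate rise beyond the scatter is therefore expected, and the estimated change is a 2.8-fold higher number from compound 3 to compound 4 (0.44 log units; beyond the scatter). For compound 4 the estimate is 50000 nM, with an expected range from 15000 nM to 250000 nM.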

Compound 4, half-maximal cytotoxic concentration in the HPC assay: > 400000 nM
Compound 4 was reported as a limit; the forecaster's own chance of this, stated with the estimate: 15%; at least 8.0-fold (0.90 log units) between middle value and limit.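

In the HPC assay, this position proves far more sensitive than the earlier swap of hydrogen for chloro suggested, which gave only a 1.3-fold higher number from compound 2 to compound 3 (0.11 log units; within the scatter); putting dimethylamino there gives an at least 22-fold higher number from compound 3 to compound 4 (1.34 log units; beyond the scatter), and an at least 28-fold higher number from compound 2 to compound 4 (1.45 log units; beyond the scatter), so toxicity in this test falls sharply, and both sizes are minimum sizes since the reading for compound 4 is a limit. Compound 1 and compound 4 both carry the 4-(dimethylamino)phenyl group and differ in where the nitro group stands on the other phenyl ring, yet the step between them cannot be read, and each reading is a limit: the limit of > 400000 nM in the HPC assay, at which 2 of the 4 values shown sit. The same change also gives a more polar compound in a physicochemical assay for lipophilicity (a lower number here means a more polar compound, a higher number a more lipophilic compound), where compound 3 gives 5.58 and compound 4 gives 5: the measured partition coefficient of compound 3, 5.58, and of compound 4, 5, a number 0.58 log units lower (beyond the scatter).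

From the compounds shown here alone, a single pair cannot show whether the drop in toxicity in this test follows that shift in polarity or belongs to dimethylamino itself, and how far compound 4 really lies beyond its limit remains unknown. A methoxy group or a primary amine on the same aromatic carbon would help separate these possibilities.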